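This account rests on a few compounds, and the source may have more. Where it says the series, first, only, none or still open, it means among the compounds named here.

Measured compounds, each value being a limit of the assay and not a number:
- compound 1 `O=C(CCSc1nnc(-c2ccncc2)s1)NCc1ccccc1Cl`: > 50000 nM
- compound 2 `CC(CSc1nnc(-c2ccncc2)s1)C(=O)NCc1ccccc1Cl`: > 50000 nM
- compound 3 `CC(CSc1nnc(-c2ccncc2)s1)C(=O)Nc1ccc(Cl)cc1Cl`: > 50000 nM

In an ADME assay on BHK-21 cells (Mesocricetus auratus) for cytotoxicity, with a stated time of 3 days (on this read-out lower numbers stand for higher toxicity in this test and higher numbers for lower toxicity in this test), compound 1 gives only a limit, > 50000 nM. The series as measured so far stands as follows: the limit of > 50000 nM in this assay, at which 3 of the 3 values shown sit.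

The next compound to be read is compound 4 `O=C(CCSc1nnc(-c2ccncc2)s1)NCc1ccc(Cl)cc1`. Its difference from compound 1 is 4-chlorophenyl in place of 2-chlorophenyl on a saturated chain carbon bound to an amide-type nitrogen.

For the measured compounds named here, two measured steps bear on this change. The closer one, also a change on an amide-type nitrogen, is a step that the two limits leave unreadable from compound 2 to compound 3. The other is a step that the two limits leave unreadable from compound 1 to compound 2. Neither has a readable size, so neither supplies a size to carry over.

Resting on compound 1 and its limit > 50000 nM, no shift beyond the scatter is expected, in either direction: a number no higher from compound 1 to compound 4 (the limit leaves the size open). The estimate for compound 4 is 50000 nM, with an expected range of 25000 nM to 100000 nM.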

Compound 4, half-maximal cytotoxic concentration: 21500 nM
The estimate for compound 4 lay 2.3-fold (0.37 log units) above the measured number; the measured number lies below the stated range.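

In this assay, for the compounds shown here, 4-chlorophenyl in place of 2-chlorophenyl on a saturated chain carbon bound to an amide-type nitrogen gives an at least 2.3-fold lower number from compound 1 to compound 4 (0.36 log units; beyond the scatter); this is the first readable step, and the earlier steps cannot be read. Going by these compounds alone, compound 4 is the first compound here to give a number and not a limit, so this place can register a change in the read-out even when the two groups hold the same atoms, joined differently. The size of the step remains a minimum, with one end resting on a limit, and most of the series still sits there: the limit of > 50000 nM in this assay, at which 3 of the 4 values shown sit.

From the compounds shown here alone, whether 4-chlorobenzyl would give a lower number with the chain methyl of compound 2 remains open. Also open, going by these compounds, is how an unsubstituted benzyl group, or a benzyl group carrying an amine or a carboxylic acid in place of chlorine, would read at this place.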